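A few compounds are considered here, and "the series" means these few. Any claim that something is new, unique, unknown or untested is made for them only; others in the source may bear on it.

Measured in a toxicity assay on NIH3T3 cells (Mus musculus) for cytotoxicity, read by resazurin assay; on this read-out lower numbers stand for an effect already at smaller amounts and higher numbers for an effect only at larger amounts of compound:
- compound 1 `COC(=O)c1ccc(NCc2cncn2Cc2ccccc2Cl)cc1-c1ccccc1`: 10000 nM
- compound 2 `COC(=O)c1ccc(NCc2cncn2Cc2ccc(C(C)(C)C)cc2)cc1-c1ccccc1`: "not determined" (no result reported)
- compound 3 `COC(=O)c1ccc(NCc2cncn2Cc2cccc(Cl)c2)cc1-c1ccccc1`: > 10000 nM (a limit)

Compound 3 gives no number, only a limit: the limit of > 10000 nM in this assay, at which 1 of the 3 values shown sits.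

Compound 4 `COC(=O)c1ccc(NCc2cncn2Cc2ccc(C#N)cc2)cc1-c1ccccc1` carries 4-cyanophenyl in place of 3-chlorophenyl on a saturated chain carbon bound to an aromatic nitrogen.

For the measured compounds named here, the only measured step that bears on this change is a number no lower from compound 1 to compound 3 (the limit leaves the size open), and its size stays open. It also concerns only the chlorine-bearing groups, so it is a thin guide for a nitrile.

Going by the values given here, the expected change is a number no higher from compound 3 to compound 4 (the limit leaves the size open), nothing beyond the scatter, resting on compound 1 with 10000 nM, the only firm number.

The value expected for compound 4 is 10000 nM, with a range from 4000 nM to 25000 nM, and it may well be reported only as a limit.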

Compound 4, half-maximal effective concentration: > 10000 nM
Compound 4: a limit, no number (the forecaster's own chance of this, stated with the estimate: 70%); the middle value lies on the limit itself.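

Moving from the chlorine-bearing groups to 4-cyanophenyl, on a saturated chain carbon bound to an aromatic nitrogen, gives in this assay a number no lower from compound 1 to compound 4 (the limit leaves the size open) and so adds a group without chlorine on the same side of compound 1 as compound 3. The step between compound 3 and compound 4 cannot be read, as both values are limits. The series now gathers at one limit: the limit of > 10000 nM in this assay, at which 2 of the 4 values shown sit.

From the compounds shown here alone, whether any group at this place gives a firm number remains open, and compound 2 offers no result. A carboxylic acid or an amine on this benzyl ring would test whether the read-out moves off the limit at all.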